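Urea series, ring substituent swap, whole-organism read-out

This account rests on a few compounds, and the source may have more. Where it says the series, first, only, none or still open, it means among the compounds named here.

Measured compounds:
- compound 1 `CC(=O)c1ccccc1NC(=O)N[C@@H](C)c1ccccc1`: 97%
- compound 2 `CC(=O)c1cccc(NC(=O)N[C@H](C)c2ccccc2)c1`: 88%
- compound 3 `C[C@H](NC(=O)Nc1ccccc1F)c1ccccc1`: 92%

In an ADME assay on the whole organism with Oryza sativa as the target, tested at 1 uM (on this read-out higher numbers stand for a weaker effect at the one concentration tested and lower numbers for a stronger effect), compound 1 gives 97%, compound 2 gives 88% and compound 3 gives 92%. All three numbers lie within the usual scatter of one another, so no ordering among them is claimed. Compound 1 and compound 2 share the same atoms joined differently; the difference between the two cores is not broken down here.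

One structural change is made twice in the set. From compound 1 to compound 3 it is fluoro in place of acetyl on an aromatic carbon, and the step it made in this assay is a number 5 percentage points lower from compound 1 to compound 3 (within the scatter). From compound 2 to the unmeasured compound 4 `C[C@@H](NC(=O)Nc1cccc(F)c1)c1ccccc1` the change is fluoro in place of acetyl on an aromatic carbon. The two changes are of the same kind but not the same: in the first the place is ortho to a large group, in the second it is meta to a large group.

Because the measured step of a number 5 percentage points lower from compound 1 to compound 3 (within the scatter) lies within the scatter, the step from compound 2 to compound 4 is expected to be small as well, about a number 4 percentage points lower from compound 2 to compound 4 (within the scatter) in this assay. Compound 4 is therefore estimated at 84%, with a range of 72% to 96% expected to hold most repeat measurements; this rests on compound 2 at 88% and on a single precedent only, so the range is kept wide.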

Compound 4, a percentage reported as activity, at one concentration (the size of the read-out at that concentration, not a potency): 95%
Compound 4: the middle estimate sits 11 percentage points below what was measured; the measured number falls inside the stated range.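

In this assay, fluoro in place of acetyl on the core of compound 2, with the fluoro meta to a large group, gives a number 7 percentage points higher from compound 2 to compound 4 (within the scatter). Set beside the earlier step, this gives no sign that the exchange behaves differently on the two cores: the same change on two cores in this assay, a number 5 percentage points lower (within the scatter) from compound 1 to compound 3 and a number 7 percentage points higher (within the scatter) from compound 2 to compound 4, 12 percentage points apart, within the scatter of two such steps As far as these two pairs go, acetyl and fluoro can be exchanged on either core without a step that stands out from the scatter, but this does not show that the exchange is without effect, that its size is the same on both cores, or that it would carry to a further core, since each step is a single pair read at one concentration and the read-out is not a potency.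

Still open is whether any group on this aromatic ring gives a step beyond the scatter, for example an amine or a carboxylic acid in place of acetyl, since the compounds shown hold only acetyl and fluoro there. Also open, on these data alone, is what a longer chain in place of the methyl group of the shared core would do to the read-out, and whether the unsubstituted phenyl ring tolerates a group such as nitrile.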